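Benzoxaborole propanamides: amide substituent and antiproliferative activity

The source may hold more compounds than are shown below. What is called first, only, known or untested is meant among the compounds shown, and "the series" means these compounds.

Measured compounds:
compound 1 `O=C(CCc1cccc2c1B(O)OC2)NC1CCCCC1` — > 100000 nM
compound 2 `Cc1ccc(NC(=O)CCc2cccc3c2B(O)OC3)cc1` — 860 nM

In a functional assay on SK-OV-3 cells (Homo sapiens) for antiproliferative activity, read by MTT assay, with a stated time of 72 h (a higher number here means a weaker inhibitor, a lower number a stronger inhibitor), compound 1 returns only a limit, > 100000 nM. Compound 2, by contrast, gives a measured number, 860 nM, the only one so far. The value of compound 1 is a limit (the limit of > 100000 nM in this assay, at which 1 of the 2 values shown sits). Among the compounds with values here, the single measured step, an at least 110-fold lower number from compound 1 to compound 2 (2.06 log units; beyond the scatter), is therefore large, and it shows that the nature of the group on the amide nitrogen governs the read-out strongly within this pair.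

Compound 3 `O=C(CCc1cccc2c1B(O)OC2)Nc1ccc(-c2ccccc2)cc1` keeps the anilide of compound 2 and alters only its substituent: phenyl in place of methyl on an aromatic carbon. Within the data shown here, no measured step compares two aromatic amide substituents, so the step from compound 1 to compound 2 bears on it only indirectly, as evidence that the aryl amide is tolerated and potent. Extending the aromatic substituent is not expected to undo that; the step of a 1.7-fold lower number from compound 2 to compound 3 (0.24 log units; within the scatter) is expected to stay within or near the scatter, perhaps slightly favourable. Compound 3 is estimated at 500 nM, with a likely range from 150 nM to 3000 nM.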

Compound 3, half-maximal inhibitory concentration: 48000 nM
Estimate against measurement, compound 3: 96-fold (1.98 log units) below; measured number above the stated range.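

In this assay, the anilide proves far less permissive than the earlier pair alone could show: a 56-fold higher number from compound 2 to compound 3 (1.75 log units; beyond the scatter). An aryl amide therefore does not secure activity by itself, and the substituent on an aromatic carbon, para to a large group, matters in its own right, whereas the earlier step spoke only to the exchange of the whole group on the amide nitrogen. Nothing shown gives a cause for this loss, so it remains an observation tied to phenyl in place of methyl in this one pair.

As far as these compounds go, two substituents on the anilide are too few to say whether the result turns on the added ring or on the reach of the substituent, so it remains open whether a single chlorine, a methoxy group or an ethyl chain at the same carbon would stay close to compound 2 at 860 nM. Also open, from the compounds shown here alone, is whether an amine or a carboxylic acid at that carbon, or a phenyl ring carried on a longer chain, would recover activity.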